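This account rests on a few compounds, and the source may have more. Where it says the series, first, only, none or still open, it means among the compounds named here.

Working notes on the series. Compound 1 is `Cc1ccc(/C=C2\CC[C@H]3C(C)(C)CCC[C@]3(C)[C@H]2CCC(C)CC(=O)O)cc1`, compound 2 is `CC(CC[C@H]1/C(=C/c2ccc([N+](=O)[O-])cc2)CC[C@H]2C(C)(C)CCC[C@]12C)CC(=O)O` and compound 3 is `CC(CC[C@H]1/C(=C/c2ccc(F)cc2)CC[C@H]2C(C)(C)CCC[C@]12C)CC(=O)O`; all three share one core and differ only in the group on the aromatic carbon. In an ADME assay on HUVEC cells (Homo sapiens) for cytotoxicity, read by MTT assay, with a stated time of 72 h (a higher number here means a weaker inhibitor, a lower number a stronger inhibitor), compound 1 gives > 200000 nM, a limit of the assay and not a number. In this assay compound 2 gives 194000 nM. In this assay compound 3 gives > 200000 nM, again a limit of the assay rather than a number. Compound 3 therefore stands at the ceiling of what this assay reports, as recorded in the limit of > 200000 nM in this assay, at which 2 of the 3 values shown sit. The measured steps are all flat: an at least 1.0-fold lower number from compound 1 to compound 2 (0.01 log units; that floor lies within the scatter), an at least 1.0-fold higher number from compound 2 to compound 3 (0.01 log units; that floor lies within the scatter), and a step that the two limits leave unreadable from compound 1 to compound 3. Compound 4 is `CC(CC[C@H]1/C(=C/c2ccc(Br)cc2)CC[C@H]2C(C)(C)CCC[C@]12C)CC(=O)O`; the change from compound 3 is bromo in place of fluoro on an aromatic carbon. Going by the values given here, none of the measured steps exchanges one such group for another, and the steps that do bear on the position, those into compound 3, stay inside the scatter or are unreadable. In this assay the expected step is a number no higher from compound 3 to compound 4 (the limit leaves the size open), no movement beyond the scatter. Compound 4 is therefore estimated at 200000 nM, with a range from 100000 nM to 400000 nM, and most likely reported again only as a limit.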

Compound 4, half-maximal inhibitory concentration: > 200000 nM
Compound 4 ended at the assay's limit (the forecaster's own chance of this, stated with the estimate: 70%); the middle value sits exactly at the limit.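

Bromo at this place, para to a large group, leaves the picture unchanged in this assay: the only readable step into the new compound is an at least 1.0-fold higher number from compound 2 to compound 4 (0.01 log units; that floor lies within the scatter). The steps to compound 4 from compound 1 and from compound 3 cannot be read, as both ends of each are limits of the assay and not numbers. Going by these compounds alone, the exchange of 4-fluorophenyl for 4-bromophenyl therefore gives no measurable separation, compound 2 with its nitro group is the only one of the four compounds to return a number rather than a limit, and the series now gathers at the ceiling: the limit of > 200000 nM in this assay, at which 3 of the 4 values shown sit.

Going by these compounds, how far compound 1, compound 3 and compound 4 lie past that limit stays open, so methyl, fluoro and bromo cannot be ranked against one another or against nitro. Also open, on these data alone, is whether an amine or a methoxy group on the same aromatic carbon, or an amide in place of the carboxylic acid at the end of the chain, would bring the number in this assay clearly down from the ceiling.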